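The compounds below may be only part of what the source reports. "The series", "measured", "known", "first", "only" and "open" are said of these compounds alone.

Measured so far in a functional assay on EBC-1 cells (Homo sapiens) for antiproliferative activity, with a stated time of 72 h; on this read-out higher numbers stand for weaker inhibition and lower numbers for stronger inhibition:
- Compound 1 `Cn1cc(-c2cc(Cl)c3ncc(Cc4ccc5ncccc5c4)n3c2)cn1`: "not determined" (no result reported)
- Compound 2 `COc1ccc(-c2cc(F)c3ncc(Cc4ccc5ncccc5c4)n3c2)cc1F`: 407 nM
- Compound 3 `CN1CCN(C(=O)c2ccc(-c3cc(F)c4ncc(Cc5ccc6ncccc6c5)n4c3)cc2F)CC1`: 869 nM

Only two of these compounds can be compared. Compound 3, at 869 nM, has the higher number of the pair, which means weaker inhibition. Compound 1 has no result, so it cannot be placed.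

The next compound is compound 4 `O=C(NCCCN1CCCC1)c1ccc(-c2cc(F)c3ncc(Cc4ccc5ncccc5c4)n3c2)cc1F`. It differs from compound 3 as follows: (3-(pyrrolidin-1-yl)propyl)amino in place of 4-methylpiperazin-1-yl on a carbonyl carbon. In words, (3-(pyrrolidin-1-yl)propyl)amino stands in place of 4-methylpiperazin-1-yl on a carbonyl carbon.

Among the measured compounds shown here, one measured step bears on this change: a 2.1-fold higher number from compound 2 to compound 3 (0.33 log units; beyond the scatter). That modest step brought in the (4-methylpiperazin-1-yl)carbonyl group, in place of methoxy on an aromatic carbon. It shows that replacing a group at this aromatic carbon has so far moved the number only a little. For the measured compounds named here, no compound other than compound 3 carries a group on that carbonyl carbon, so the data give no direction for the new change. A small step in this assay therefore seems most likely, with none beyond the scatter expected.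

The estimated change is a 1.2-fold lower number from compound 3 to compound 4 (0.06 log units; within the scatter). For compound 4 the expected value is 750 nM, with an estimated range of 250 nM to 2300 nM.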

Compound 4, half-maximal inhibitory concentration: 161 nM
The estimate for compound 4 lay 4.7-fold (0.67 log units) above the measured number, and the stated range ends above it.
By their numbers in this assay, from the lowest: compound 4; then compound 2; then compound 3.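

In this assay, among the compounds shown here, the change on the carbonyl carbon gives a 5.4-fold lower number from compound 3 to compound 4 (0.73 log units; beyond the scatter), the first reading of how much the group at this spot matters, since the earlier compounds with a number offered only one group there. The (3-(pyrrolidin-1-yl)propyl)carbamoyl group also gives a 2.5-fold lower number from compound 2 to compound 4 (0.40 log units; beyond the scatter), whereas (4-methylpiperazin-1-yl)carbonyl gave a 2.1-fold higher number from compound 2 to compound 3 (0.33 log units; beyond the scatter), so replacing methoxy on the aromatic carbon can move the number either way, depending on what the carbonyl carbon carries. No measurement shown explains the difference between these two groups.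

This single change brings in an amide hydrogen, replaces the six-membered ring with a five-membered ring and adds a propyl chain, and the compounds shown do not separate these features. A shorter chain ending in the same pyrrolidine, or a dimethylamino group at the end of the propyl chain, would help show which of these features goes with the lower number.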